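Propyl in place of ethoxy on an aromatic carbon

The compounds below may be only part of what the source reports. "The series", "measured", "known", "first", "only" and "open" are said of these compounds alone.

Compound 1 `O=C1C(Nc2ccccc2)=CC(=O)c2c1nc1n2[C@H]2OC[C@@H](O)[C@H]2OC1`: 3560 nM
Compound 2 `CCOc1ccc(NC2=CC(=O)c3c(nc4n3[C@H]3OC[C@@H](O)[C@H]3OC4)C2=O)cc1`: > 4000 nM, a limit of the assay
Compound 3 `CCCc1ccc(NC2=CC(=O)c3c(nc4n3[C@H]3OC[C@@H](O)[C@H]3OC4)C2=O)cc1`: not yet measured

In a functional assay on ECa-109 cells for inhibition, with ECa-109 cell line (Homo sapiens) as the target, read by sulforhodamine B assay (on this read-out higher numbers stand for weaker inhibition and lower numbers for stronger inhibition), compound 1 gives 3560 nM. For compound 2 the reading is a limit and not a number, > 4000 nM, and this is the limit of > 4000 nM in this assay, at which 1 of the 2 values shown sits. So compound 2 has no exact standing on the numbers shown.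

The next change is propyl in place of ethoxy on an aromatic carbon, which puts propyl in place of ethoxy on an aromatic carbon. Within the data shown here, only one measured step bears on it, the one that placed ethoxy at this same carbon: an at least 1.1-fold higher number from compound 1 to compound 2 (0.05 log units; that floor lies within the scatter). That step rests on a limit, and its floor does not rise beyond the scatter. Among the measured compounds shown here, nothing measured therefore gives a size for a change at this place, and no measured step replaces ethoxy with another group.

In this assay no shift beyond the scatter is expected, so the estimated size is a number no higher from compound 2 to compound 3 (the limit leaves the size open). Compound 3 may also read as a limit. Compound 3 is estimated at 4000 nM, with an expected range from 1800 nM to 9000 nM.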

Compound 3, half-maximal inhibitory concentration: > 4000 nM
Compound 3: a limit, no number (the forecaster's own chance of this, stated with the estimate: 50%); the middle value lies on the limit itself.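

In this assay, compound 3 gives > 4000 nM, which is a limit of the assay and not a number, so propyl, like ethoxy before it, leaves no exact reading at this aromatic carbon. Propyl in place of hydrogen gives an at least 1.1-fold higher number from compound 1 to compound 3 (0.05 log units; that floor lies within the scatter), so a second group now shows a floor no larger than the scatter, and this time the group holds carbon only, with no oxygen. The step from ethoxy to propyl cannot be read, because both readings are limits: the limit of > 4000 nM in this assay, at which 2 of the 3 values shown sit.

The compounds shown leave open how far compound 2 and compound 3 truly lie from compound 1, and whether either differs from the other at all. They also leave open whether a different group on this carbon, such as an amine, a carboxylic acid or a fluorine atom, would give a number rather than a limit in this assay.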